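Trading trifluoromethyl for cyano in a cytotoxicity series

The compounds below may be only part of what the source reports. "The series", "measured", "known", "first", "only" and "open" are said of these compounds alone.

compound 1 `Cc1cnc(Nc2ccc(C#N)cc2)nc1Nc1c(F)cc(-c2cc(F)nc(F)c2)cc1F`: 103000 nM
compound 2 `Cc1cnc(Nc2ccc(C#N)cc2)nc1Nc1c(F)cc(-c2cncc(C(F)(F)F)c2)cc1F`: 8200 nM

In a toxicity assay on MT4 cells (Homo sapiens) for cytotoxicity, read by MTT assay, with a stated time of 5 days (on this read-out higher numbers stand for lower toxicity in this test and lower numbers for higher toxicity in this test), compound 2, at 8200 nM, has the lower of the two numbers, which makes it the more toxic of the pair. The next molecule, compound 3 `Cc1cnc(Nc2ccc(C#N)cc2)nc1Nc1c(F)cc(-c2cncc(C#N)c2)cc1F`, keeps the shared core and changes one small group: cyano in place of trifluoromethyl on an aromatic carbon. In words, cyano takes the place of trifluoromethyl on an aromatic carbon. Within the data shown here, only one measured step bears on this, a 13-fold lower number from compound 1 to compound 2 (1.10 log units; beyond the scatter). Among the measured compounds shown here, that large step replaced the whole substituent, whereas here only one group on it changes, so a smaller step is expected in this assay. For the measured compounds named here, with no measured cyano compound to guide the direction, a modest rise is the tentative expectation, back toward compound 1. The estimated change is a 2.2-fold higher number from compound 2 to compound 3 (0.34 log units; beyond the scatter). For compound 3 the estimated value is 18000 nM, with an expected range of 5000 nM to 60000 nM.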

Compound 3, half-maximal cytotoxic concentration: 50000 nM
Compound 3: the middle estimate sits 2.8-fold (0.44 log units) below what was measured; the measured number falls inside the stated range.
By their numbers in this assay, from the lowest: compound 2; then compound 3; then compound 1.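

In this assay, changing only trifluoromethyl to cyano gives a 6.1-fold higher number from compound 2 to compound 3 (0.79 log units; beyond the scatter), so swapping one small group at this position, with the rest of the molecule unchanged, is enough to move the number clearly toward lower toxicity. The comparison of whole substituents also gains a second point, a 2.1-fold lower number from compound 1 to compound 3 (0.31 log units; beyond the scatter), which places compound 3 between the other two and closer to compound 1 on this read-out. Nothing measured here speaks to why the number moves.

Going by these compounds, it remains open how other groups at this position, such as an amine, a carboxylic acid or a methoxy group, would fall relative to cyano and trifluoromethyl. On these data alone, whether the same swap would shift the number similarly at another position on this ring also remains unknown.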